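A few compounds are considered here, and "the series" means these few. Any claim that something is new, unique, unknown or untested is made for them only; others in the source may bear on it.

Two compounds of the series carry measured numbers. Compound 1 `CCc1cc(C(C)=O)c(OC2CCCC2)cc1OCCCCCC(C)(C)c1nnn[nH]1` gives 3300 nM in an assay on isolated protein for antagonist activity at Bile acid receptor (Homo sapiens), read by HTRF, with a stated time of 30 min; a higher number here means a weaker inhibitor, a lower number a stronger inhibitor. Compound 2 `CCCc1cc(C(C)=O)c(O)cc1OCCCCCC(C)(C)c1nnn[nH]1` gives 25200 nM in this assay, the higher of the two numbers; the gap to compound 1 lies beyond the scatter, though the two structures differ at more than one place. Compound 3 `CCCCCCc1cc(C(C)=O)c(O)cc1OCCCCCC(C)(C)c1nnn[nH]1` is the next to be measured. It differs from compound 2 by propyl in place of hydrogen on a saturated chain carbon, three bonds along the chain from an aromatic carbon. Going by the values given here, no measured pair shows this change alone, so only a modest step is expected: the step of a 1.7-fold lower number from compound 2 to compound 3 (0.23 log units; within the scatter) is expected to be small and toward a lower number. Compound 3 is estimated at 15000 nM, within 5000 nM to 40000 nM.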

Compound 3, half-maximal inhibitory concentration: 3200 nM
For compound 3 the middle estimate is 4.7-fold (0.67 log units) above the measured one, and the stated range ends above it.
By their numbers in this assay, from the lowest: compounds 3 and 1 (each within the scatter of the next); then compound 2.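

Going by these compounds alone, the first single-place reading at this position is propyl in place of hydrogen on a saturated chain carbon, three bonds along the chain from an aromatic carbon, which turns propyl into hexyl and gives a 7.9-fold lower number from compound 2 to compound 3 (0.90 log units; beyond the scatter) in this assay. The number at this position therefore responds to chain length, with added carbon alone moving it beyond the scatter. No measurement bears on the reason for this step. On these data alone, whether a chain longer than hexyl, or an amine or a carboxylic acid in place of hexyl, would move the number further stays open.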